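From isopropyl to tert-butyl in one inhibitor series

This account rests on a few compounds, and the source may have more. Where it says the series, first, only, none or still open, it means among the compounds named here.

compound 1 `Cc1ccc(C(=O)CC(SCC(=O)O)C(=O)O)cc1` (17300 nM)
compound 2 `CCc1ccc(C(=O)CC(SCC(=O)O)C(=O)O)cc1` (4790 nM)
compound 3 `CC(C)c1ccc(C(=O)CC(SCC(=O)O)C(=O)O)cc1` (3330 nM)

In a functional assay on HeLa cells (Homo sapiens) for inhibition (on this read-out higher numbers stand for weaker inhibition and lower numbers for stronger inhibition), compound 3 reads 3330 nM and stands well clear of the highest number (a 5.2-fold lower number from compound 1 to compound 3 (0.72 log units; beyond the scatter)) but level with its nearest neighbour (a 1.4-fold lower number from compound 2 to compound 3 (0.16 log units; within the scatter)). Compound 4 `CC(C)(C)c1ccc(C(=O)CC(SCC(=O)O)C(=O)O)cc1` carries one change (methyl in place of hydrogen on a saturated chain carbon bound to an aromatic carbon and two saturated chain carbons): methyl in place of hydrogen on a saturated chain carbon bound to an aromatic carbon and two saturated chain carbons, isopropyl to tert-butyl. Two earlier methyl additions bear on it: the first was modest (a 3.6-fold lower number from compound 1 to compound 2 (0.56 log units; beyond the scatter)), the second within the scatter (a 1.4-fold lower number from compound 2 to compound 3 (0.16 log units; within the scatter)). A small further drop, probably within the scatter, is therefore expected (a 1.3-fold lower number from compound 3 to compound 4 (0.11 log units; within the scatter)). Compound 4 is estimated at 2600 nM with an expected range of 1100 nM to 6000 nM in this read-out.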

Compound 4, half-maximal inhibitory concentration: 1390 nM
Compound 4: the middle estimate sits 1.9-fold (0.27 log units) above what was measured; the measured number falls inside the stated range.
By their numbers in this assay, from the lowest: compound 4; then compounds 3 and 2 (each within the scatter of the next); then compound 1.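

In this assay the added methyl on this saturated chain carbon counts again, with a 2.4-fold lower number from compound 3 to compound 4 (0.38 log units; beyond the scatter), so the small step at the isopropyl group does not carry through to tert-butyl. The steps of a 3.4-fold lower number from compound 2 to compound 4 (0.54 log units; beyond the scatter) and a 12-fold lower number from compound 1 to compound 4 (1.10 log units; beyond the scatter) make the run from methyl to tert-butyl a large one overall, although compounds 2 and 3 stand within the scatter of each other and break any even trend. The last addition matches the first in size: the same change on two cores in this assay, a 3.6-fold lower number (0.56 log units; beyond the scatter) from compound 1 to compound 2 and a 2.4-fold lower number (0.38 log units; beyond the scatter) from compound 3 to compound 4, 1.5-fold (0.18 log units) apart, within the scatter of two such steps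

The compounds leave open whether a cyclohexyl or a phenyl in place of tert-butyl would carry the number lower still, or whether the series ends at tert-butyl.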